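A few compounds are considered here, and "the series" means these few. Any claim that something is new, unique, unknown or untested is made for them only; others in the source may bear on it.

In a functional assay on HCT-116 cells (Homo sapiens) for inhibition, read by MTT assay, with a stated time of 48 h (a lower number here means a stronger inhibitor, a higher number a weaker inhibitor), compound 1 (`COc1ccc(CN(C(=O)C=C(C)C)c2cc(OC)c(OC)c(OC)c2)cc1O`) gives 290 nM. Compound 2 (`C/C=C/C(=O)N(Cc1cccc(O)c1)c1cc(OC)c(OC)c(OC)c1`) gives 6700 nM, so compound 1 holds the lower of the two numbers, by a gap beyond the usual scatter. The next structure, compound 3 (`COc1ccc(CN(C(=O)CCCl)c2cc(OC)c(OC)c(OC)c2)cc1O`), keeps the core of compound 1 and alters only the group on the carbonyl carbon: 2-chloroethyl in place of 2-methylprop-1-en-1-yl on a carbonyl carbon. In words, 2-chloroethyl stands in place of 2-methylprop-1-en-1-yl on a carbonyl carbon. For the measured compounds named here, no measured pair here isolates this change, so any expectation for it remains loose. A weaker result is expected, with a rise in the number somewhat beyond the scatter, and the estimated change is a 4.1-fold higher number from compound 1 to compound 3 (0.62 log units; beyond the scatter). For compound 3 the estimated value is 1200 nM, with an expected range from 250 nM to 6000 nM.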

Compound 3, half-maximal inhibitory concentration: 150 nM
Estimate against measurement, compound 3: 8.0-fold (0.90 log units) above; measured number outside the range, below it.
By their numbers in this assay, from the lowest: compounds 3 and 1 (each within the scatter of the next); then compound 2.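

In this assay, replacing 2-methylprop-1-en-1-yl with 2-chloroethyl on a carbonyl carbon gives a 1.9-fold lower number from compound 1 to compound 3 (0.29 log units; within the scatter), and this step lies within the scatter. For the compounds shown here, this is the first pair to isolate this position, and it shows that activity in this assay is kept when the double bond outside aromatic rings leaves and a chlorine enters, so the two groups cannot be told apart here. Nothing measured here offers a reason for this outcome.

The compounds shown leave open how this position responds to other groups on the carbonyl carbon, such as a longer chain, an amine or a carboxylic acid. They also leave open whether the two groups would stay equal with other changes elsewhere on the core of compound 1.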